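The source may report more compounds than this note shows. Statements on the series, on what has been measured and on what is new or still open speak of the compounds shown alone.

Of the compounds shown here, three of one series have been tested in an assay on CHO cells for displacement of a labelled ligand from adenosine receptor A3 (Homo sapiens), read by scintillation counting, with a stated time of 120 min, tested at 1 uM; a higher number here means more inhibition at the concentration tested (going by the name of the read-out), a lower number less inhibition. Compound 1 `N#Cc1c(N)nc2sc(C(N)=O)c(N)c2c1-c1ccc(OCC2CC2)cc1` gives 13% in that assay. Compound 2 `N#Cc1c(N)nc(SCC(=O)NCO)c(C#N)c1-c1ccc(OCC2CC2)cc1` gives 8%, and compound 3 `C=C(C)COc1ccc(-c2c(C#N)c(N)nc(SCC(N)=O)c2C#N)cc1` gives 4%. Compound 2 thus stands second among the three numbers, but its distance to compound 3 and to compound 1 both lie within the scatter of repeated measurements, so no order among the three can be claimed; all three show only small inhibition at the tested concentration.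

Compound 4 `N#Cc1c(N)nc(SCc2cnc[nH]2)c(C#N)c1-c1ccc(OCC2CC2)cc1` has not been measured yet. It differs from compound 2 in one place: 1H-imidazol-5-yl in place of (hydroxymethyl)carbamoyl on a saturated chain carbon bound to a sulfur. Within the data shown here, nothing among the measured compounds shows how such an exchange affects the read-out, and since the three measured numbers sit close together, the step is estimated to be small, with no clear direction; the expected step is a number 2 percentage points higher from compound 2 to compound 4 (within the scatter), which does not exceed the scatter. For compound 4 the expected value in this assay is therefore 10%, with a range from 0% to 25%.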

Compound 4, a percentage reported as inhibition, at one concentration (the size of the read-out at that concentration, not a potency): 1%
The estimate for compound 4 lay 9 percentage points above the measured number; the range from low to high includes it.
By their numbers in this assay, from the lowest: compounds 4, 3, 2 and 1 (each within the scatter of the next, the first and the last beyond it).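

In this assay, among these compounds, putting 1H-imidazol-5-yl in place of (hydroxymethyl)carbamoyl on a saturated chain carbon bound to a sulfur gives a number 7 percentage points lower from compound 2 to compound 4 (within the scatter) and so provides the first reading of a change at this place. An open group with no ring and a five-membered aromatic ring, each of 5 heavy atoms, therefore cannot be told apart in this assay, although they differ in their hydrogen-bond donor and acceptor counts. Nothing shown explains the step or says how either group acts on the receptor.

Going by these compounds, it remains open whether a carboxylic acid, a primary amine or a longer alkyl chain at this place would give a step beyond the scatter. A six-membered ring such as pyridine in place of the 1H-imidazol-5-yl also remains untested among the compounds shown.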